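From trifluoromethyl to chloro on the benzoyl group

The source may hold more compounds than are shown below. What is called first, only, known or untested is meant among the compounds shown, and "the series" means these compounds.

In a functional assay on Bel-7402 cells (Homo sapiens) for cytotoxicity, read by MTT assay, with a stated time of 72 h (on this read-out higher numbers stand for weaker inhibition and lower numbers for stronger inhibition), compound 1 `C=C1C(=O)[C@@]23C(=O)OC[C@]4(C(=O)CCC(C)(C)[C@H]4C=O)[C@@H]2CC[C@@H]1[C@H]3O` gives 5030 nM. Placing a benzoyl group on its free oxygen yields compound 2 `C=C1C(=O)[C@@]23C(=O)OC[C@]4(C(=O)CCC(C)(C)[C@H]4C=O)[C@@H]2CC[C@@H]1[C@H]3OC(=O)c1ccccc1`, which gives 1850 nM: a 2.7-fold lower number from compound 1 to compound 2 (0.43 log units; beyond the scatter). Compound 3 `C=C1C(=O)[C@@]23C(=O)OC[C@]4(C(=O)CCC(C)(C)[C@H]4C=O)[C@@H]2CC[C@@H]1[C@H]3OC(=O)c1ccc(C(F)(F)F)cc1` carries a trifluoromethyl group on that benzoyl ring and gives 3990 nM. This value stands level with that of the unacylated starting point, a 1.3-fold lower number from compound 1 to compound 3 (0.10 log units; within the scatter), while the trifluoromethyl group itself accounts for a 2.2-fold higher number from compound 2 to compound 3 (0.33 log units; beyond the scatter).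

Compound 4 `C=C1C(=O)[C@@]23C(=O)OC[C@]4(C(=O)CCC(C)(C)[C@H]4C=O)[C@@H]2CC[C@@H]1[C@H]3OC(=O)c1ccc(Cl)cc1` changes one thing: chloro in place of trifluoromethyl on an aromatic carbon. In words, this is chloro in place of trifluoromethyl on an aromatic carbon. Going by the values given here, no measured step makes this exact swap, so the evidence is indirect. The closest guide is the modest step between the two benzoyl compounds, which shows that this ring position can move the number only a little. Compound 4 is therefore expected to fall around the span from compound 2 at 1850 nM to compound 3 at 3990 nM. The expected step is a 1.5-fold lower number from compound 3 to compound 4 (0.17 log units; within the scatter), small in size and towards a lower number. Compound 4 is estimated at 2700 nM, with an expected range of 1300 nM to 5500 nM.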

Compound 4, half-maximal inhibitory concentration: 3840 nM
Beside the measured number, compound 4's estimate is 1.4-fold (0.15 log units) below it; low and high end bracket the measured number.
By their numbers in this assay, from the lowest: compound 2; then compounds 4, 3 and 1 (each within the scatter of the next).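

In this assay, chloro and trifluoromethyl cannot be told apart at this ring position (a 1.0-fold lower number from compound 3 to compound 4 (0.02 log units; within the scatter)), so two different groups now read alike there. Chloro also gives a higher number than hydrogen at the same position (a 2.1-fold higher number from compound 2 to compound 4 (0.32 log units; beyond the scatter)), and the ester carrying it stands level with the free alcohol (a 1.3-fold lower number from compound 1 to compound 4 (0.12 log units; within the scatter)), so the advantage of plain benzoyl in compound 2 is lost with both ring groups shown. No supporting data bear on what lies behind this.

From the compounds shown here alone, it remains open whether an amine or a carboxylic acid at this ring position would also raise the number or would match compound 2. Also unsettled is how a longer alkyl chain on the oxygen, in place of the benzoyl ring, would compare.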